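The compounds below may be only part of what the source reports. "The series", "measured", "known", "first", "only" and "open" are said of these compounds alone.

In a functional assay on MCF7 cells (Homo sapiens) for antiproliferative activity (on this read-out higher numbers stand for weaker inhibition and lower numbers for stronger inhibition), compound 1 (`CO[C@@H]1[C@@H](O)[C@@H](O)[C@H](Oc2ccc3c(c2C)OC(=O)C(n2cc(-c4ccc(C)cc4)nn2)C3)OC1(C)C`) gives > 100000 nM, which is a limit of the assay and not a number. Compound 2 (`CO[C@@H]1[C@@H](O)[C@@H](O)[C@H](Oc2ccc3c(c2C)OC(=O)C(n2cc(-c4ccc(F)cc4F)nn2)C3)OC1(C)C`) gives > 100000 nM, which is likewise only a limit. The record so far is therefore (the limit of > 100000 nM in this assay, at which 2 of the 2 values shown sit), and compound 2 has no measured potency of its own.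

Compound 3 (`CO[C@@H]1[C@@H](O)[C@@H](O)[C@H](Oc2ccc3c(c2C)OC(=O)C(n2cc(/C=C/c4ccccc4)nn2)C3)OC1(C)C`) carries 2-phenylethenyl in place of 2,4-difluorophenyl on an aromatic carbon of the five-membered aromatic ring with 3 nitrogen: 2-phenylethenyl in place of 2,4-difluorophenyl on an aromatic carbon. For the measured compounds named here, the only measured step that bears on this change is a step that the two limits leave unreadable from compound 1 to compound 2, which also exchanges the group on that ring, so it offers no size to carry over. The step expected in this assay is a number no higher from compound 2 to compound 3 (the limit leaves the size open), with no firm direction. Compound 3 is estimated at 100000 nM, with an expected range from 30000 nM to 300000 nM.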

Compound 3, half-maximal inhibitory concentration: 14600 nM
Compound 3: the middle estimate sits 6.8-fold (0.84 log units) above what was measured, outside the stated range (below it).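

On this carbon of the five-membered aromatic ring with 3 nitrogen, the group can shift the read-out in this assay: 2-phenylethenyl in place of 2,4-difluorophenyl gives an at least 6.8-fold lower number from compound 2 to compound 3 (0.83 log units; beyond the scatter), and in place of 4-methylphenyl it gives an at least 6.8-fold lower number from compound 1 to compound 3 (0.83 log units; beyond the scatter). This exchange leaves the count of heavy atoms unchanged and keeps a six-membered aromatic ring of carbon only, while adding a double bond outside aromatic rings. The step from compound 1 to compound 2 cannot be read, and those two compounds show only a limit of the assay and not a number: the limit of > 100000 nM in this assay, at which 2 of the 3 values shown sit.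

Going by these compounds, the true sizes of both readable steps remain open, as does whether the double bond or some other feature of 2-phenylethenyl accounts for them. On these data alone, how a saturated 2-phenylethyl chain, or an amine or a carboxylic acid on the phenyl ring of compound 3, would behave also remains unknown.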